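The source may report more compounds than this note shows. Statements on the series, on what has been measured and on what is new or still open speak of the compounds shown alone.

Compound 3 `CCCCc1ccc(CN(C)S(=O)(=O)c2ccccc2)c(=O)n1Cc1ccc(-c2ccccc2-c2nn[nH]n2)cc1` gives 2 nM in a functional assay (aorta) for antagonist activity, with Oryctolagus cuniculus as the target; on this read-out higher numbers stand for weaker inhibition and lower numbers for stronger inhibition. It stands level with compound 2 `CCCCc1ccc(CNS(C)(=O)=O)c(=O)n1Cc1ccc(-c2ccccc2-c2nn[nH]n2)cc1`, which gives 2 nM, and together they hold the lowest of the three numbers; compound 1 `CCCCc1ccc(CNC(=O)OC(C)(C)C)c(=O)n1Cc1ccc(-c2ccccc2-c2nn[nH]n2)cc1` gives 10 nM, and a 5.0-fold lower number from compound 1 to compound 3 (0.70 log units; beyond the scatter). Compound 4 `CCCCc1ccc(CN(C)S(C)(=O)=O)c(=O)n1Cc1ccc(-c2ccccc2-c2nn[nH]n2)cc1` differs from compound 3 by methyl in place of phenyl on a sulfonyl sulfur. The step that bears most directly on this change is no change at the digits printed from compound 2 to compound 3 (within the scatter), where a methanesulfonamido group and a methyl(phenylsulfonyl)amino group gave the same number. The other step, a 5.0-fold lower number from compound 1 to compound 2 (0.70 log units; beyond the scatter), concerns the tert-butoxycarbonyl group and is less relevant. Because no change at the digits printed from compound 2 to compound 3 (within the scatter) showed no change, the expected step is no change at the digits printed from compound 3 to compound 4 (within the scatter), nothing beyond the scatter. Compound 4 is therefore estimated at 2 nM, within a range from 1 nM to 5 nM.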

Compound 4, half-maximal inhibitory concentration: 0.2 nM
Compound 4: middle estimate off by 10-fold (1.00 log units), on the high side, and the stated range ends above it.
By their numbers in this assay, from the lowest: compound 4; then compounds 2 and 3 (each within the scatter of the next); then compound 1.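

The level numbers of compound 2 and compound 3 turn out to conceal two changes that offset each other: methyl in place of hydrogen on the sulfonamide nitrogen gives a 10-fold lower number from compound 2 to compound 4 (1.00 log units; beyond the scatter), and methyl in place of phenyl on the sulfonyl sulfur gives a 10-fold lower number from compound 3 to compound 4 (1.00 log units; beyond the scatter). Set against the (tert-butoxycarbonyl)amino group, the methyl(methylsulfonyl)amino group gives a 50-fold lower number from compound 1 to compound 4 (1.70 log units; beyond the scatter), the largest step among these compounds. Nothing measured here gives a reason for these steps.

Still open, going by these compounds, is whether an ethyl group on the sulfonamide nitrogen, or an ethyl or trifluoromethyl group on the sulfonyl sulfur, would keep the number this low.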